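The source may hold more compounds than are shown below. What is called first, only, known or untested is meant among the compounds shown, and "the series" means these compounds.

Measured compounds:
- Compound 1 `COc1cc(-c2cc(C(=O)O)c3ccccc3n2)ccc1OCC(=O)Nc1ccc(C)cc1` gives 1.2 in a physicochemical assay for lipophilicity, using the shake flask method, in phosphate buffer, measured as octanol-water partition, at pH 7.4; a lower number here means a more polar compound, a higher number a more lipophilic compound.
- Compound 2 `COc1cc(-c2cc(C(=O)O)c3ccccc3n2)ccc1OCC(=O)Nc1cccc(F)c1` gives 1.6 in this assay.
- Compound 3 `COc1cc(-c2cc(C(=O)O)c3ccccc3n2)ccc1OCC(=O)Nc1ccccc1Cl` gives 1.6 in this assay.

Compound 1 stands lowest of the three in this assay; compound 2 and compound 3 sit together above it. The two steps away from compound 1 both go up: a number 0.40 log units higher from compound 1 to compound 2 (beyond the scatter) and a number 0.40 log units higher from compound 1 to compound 3 (beyond the scatter). Between the two halogenated anilides there is nothing to separate, no change at the digits printed from compound 2 to compound 3 (within the scatter).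

Compound 4 `COc1cc(-c2cc(C(=O)O)c3ccccc3n2)ccc1OCC(=O)Nc1cccc(C(F)(F)F)c1` is the next member of the series. The change from compound 1 is 3-(trifluoromethyl)phenyl in place of 4-methylphenyl on an amide-type nitrogen, so again the 4-methylphenyl on the amide-type nitrogen is replaced by a substituted phenyl, here a 3-(trifluoromethyl)phenyl. The two measured steps that bear on this are those from compound 1 to compound 2 and from compound 1 to compound 3; both were modest rises of the same size. On that basis the expected step is in the same direction, a number 0.50 log units higher from compound 1 to compound 4 (beyond the scatter), with the wider range allowing for a somewhat larger rise than the two halogen cases showed. Compound 4 is therefore estimated at 1.7 in this assay, between 1.3 and 2.1.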

Compound 4, distribution coefficient: 1.3
The estimate for compound 4 lay 0.40 log units above the measured number; the measured number falls inside the stated range.
By their numbers in this assay, from the lowest: compounds 1, 4, 2 and 3 (each within the scatter of the next, the first and the last beyond it).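

Replacing 4-methylphenyl with 3-(trifluoromethyl)phenyl on the amide-type nitrogen brings in 10 heavy atoms in place of 7, yet the result is a number 0.10 log units higher from compound 1 to compound 4 (within the scatter) and so, unlike the two halogenated anilides, this change does not separate from compound 1. Compound 4 does not separate from those two anilides either, with a number 0.30 log units lower from compound 3 to compound 4 (within the scatter) and a number 0.30 log units lower from compound 2 to compound 4 (within the scatter) as the steps. The four compounds therefore form a chain in which only compound 1 against compound 2 and compound 3 lies beyond the scatter, and trifluoromethyl in place of fluoro does not go with a higher number here.

On these data alone, whether a dimethylamino group or a nitrile on this phenyl would give a step beyond the scatter stays open. The group and its place on the ring change together in most of these pairs, and nothing measured on these compounds accounts for the steps.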